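The compounds below may be only part of what the source reports. "The series", "measured", "known", "first", "only" and "open" are said of these compounds alone.

Compound 1 `COC(=O)c1cccc(CC[C@H]([C@H](C)O)n2cnc3c(N)ncnc32)c1` gives 2.2 nM in an assay on isolated protein for inhibition of adenosine deaminase (Bos taurus), with a stated time of 5 min; on this read-out lower numbers stand for stronger inhibition and higher numbers for weaker inhibition. Going by the values given here, compound 2 `C[C@H](O)[C@@H](CCc1cccc(-c2nccs2)c1)n1cnc2c(N)ncnc21` gives 2.6 nM in this assay, and the step of a 1.2-fold higher number from compound 1 to compound 2 (0.07 log units; within the scatter) leaves the two values within the scatter of each other, so on these numbers compound 2 is not separated from its only neighbour. Compound 3 `C[C@H](O)[C@@H](CCc1cccc(-c2cnccn2)c1)n1cnc2c(N)ncnc21` differs from compound 2 by pyrazin-2-yl in place of 1,3-thiazol-2-yl on an aromatic carbon. Among the compounds with values here, the one measured step that bears on a change at this position, a 1.2-fold higher number from compound 1 to compound 2 (0.07 log units; within the scatter), stayed within the scatter, so no step beyond the scatter is expected in this assay. The expected change is a 1.2-fold higher number from compound 2 to compound 3 (0.06 log units; within the scatter). Compound 3 is thus estimated at 3 nM, in a range from 1.4 nM to 7 nM.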

Compound 3, inhibition constant: 1.9 nM
Compound 3: the middle estimate sits 1.6-fold (0.20 log units) above what was measured; the measured number falls inside the stated range.
By their numbers in this assay, from the lowest: compounds 3, 1 and 2 (each within the scatter of the next).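

In this assay pyrazin-2-yl in place of 1,3-thiazol-2-yl gives a 1.4-fold lower number from compound 2 to compound 3 (0.14 log units; within the scatter) and in place of methoxycarbonyl gives a 1.2-fold lower number from compound 1 to compound 3 (0.06 log units; within the scatter). A six-membered aromatic ring is thus taken at this place as well as a five-membered one, and on these numbers the three groups cannot be told apart. No measurement shown gives a reason for this. Going by these compounds, whether an amine, a carboxylic acid or a longer chain at this place would move the number beyond the scatter stays open, as does whether any group here separates from these three.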